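Shared core with trimethoxyphenyl arm: methoxy replaces tert-butyl

The source may report more compounds than this note shows. Statements on the series, on what has been measured and on what is new or still open speak of the compounds shown alone.

Values in a functional assay on HeLa cells (Homo sapiens) for inhibition, read by CCK-8 assay, with a stated time of 48 h; a higher number here means a weaker inhibitor, a lower number a stronger inhibitor:
compound 1, `COc1cc(-c2ccnc3c(-c4ccc(C)cc4)cnn23)cc(OC)c1OC` — a limit only, > 10000 nM
compound 2, `COc1ccc(-c2cc3nccc(-c4cc(OC)c(OC)c(OC)c4)n3n2)cc1[N+](=O)[O-]` — a limit only, > 10000 nM
compound 3, `COc1cc(-c2ccnc3cc(-c4ccc(C(C)(C)C)cc4)nn23)cc(OC)c1OC` — a limit only, > 10000 nM

Compound 3 stands nowhere distinct on these numbers: its value is a limit, and the two other values shown are limits as well, all sitting at the limit of > 10000 nM in this assay, at which 3 of the 3 values shown sit. For the measured compounds named here, no measured pair differs in a single place, so no step has a size, and the series gives no direction of its own. Every compound made so far on the shared core has failed to reach the measurable range of this assay.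

Compound 4 is `COc1ccc(-c2cc3nccc(-c4cc(OC)c(OC)c(OC)c4)n3n2)cc1` and is not yet measured. Its difference from compound 3 is methoxy in place of tert-butyl on an aromatic carbon; cut one bond further out, the change reads 4-(tert-butyl)phenyl to 4-methoxyphenyl. Compound 1 and compound 2 carry differently substituted aryl groups on the same core and neither reaches the range of this assay, so a methoxy on that ring is not expected to open up inhibition. The expected step is a step that the limit leaves unreadable from compound 3 to compound 4, none beyond the scatter, with the result most likely again a limit. Compound 4 is estimated at 15000 nM in this assay, within 5000 nM to 50000 nM.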

Compound 4, half-maximal inhibitory concentration: 373 nM
Beside the measured number, compound 4's estimate is 40-fold (1.60 log units) above it, outside the stated range (below it).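

In this assay, the aryl ring on the shared core turns out to be a place where a single change decides whether a value can be read at all: methoxy in place of tert-butyl on an aromatic carbon gives an at least 26-fold lower number from compound 3 to compound 4 (1.42 log units; beyond the scatter). The same ring responds to a second change, as hydrogen in place of nitro on an aromatic carbon gives an at least 26-fold lower number from compound 2 to compound 4 (1.42 log units; beyond the scatter). Compound 4 is thus the only compound shown with a measured number, and the others remain limits: the limit of > 10000 nM in this assay, at which 3 of the 4 values shown sit.

Both steps start from a limit, so their full size cannot be read, and the compounds shown do not separate what the methoxy itself contributes from what the loss of the tert-butyl or the nitro contributes. From the compounds shown here alone, it remains open whether a hydroxyl, a fluorine or an amine on that ring would match compound 4 at 373 nM, and whether the trimethoxyphenyl arm can be changed without losing that value.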